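Compound 2 and its acetamido group in the heptyloxy series

A few compounds are considered here, and "the series" means these few. Any claim that something is new, unique, unknown or untested is made for them only; others in the source may bear on it.

In a functional assay on HT-29 cells (Homo sapiens) for antiproliferative activity, read by sulforhodamine B assay, with a stated time of 72 h (on this read-out lower numbers stand for stronger inhibition and higher numbers for weaker inhibition), compound 2 `CCCCCCCOc1ccc(CCC(CO)(CO)NC(C)=O)c2ccccc12` gives 17600 nM, the lower of the two numbers, and compound 1 `CCCCCCCCc1ccc(CCC(CO)(CO)NC(C)=O)c2ccccc12` gives 36500 nM. Compound 3 `CCCCc1ccc(Oc2ccc(CCC(CO)(CO)NC(C)=O)c3ccccc23)cc1` is recorded only as a limit, > 80000 nM.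

Compound 4 `CCCCCCCOc1ccc(CCC(CO)(CO)NC(=O)OC(C)(C)C)c2ccccc12` has tert-butoxy in place of methyl on a carbonyl carbon, turning acetamido into (tert-butoxycarbonyl)amino. Heptyloxy in place of octyl gave a 2.1-fold lower number from compound 1 to compound 2 (0.32 log units; beyond the scatter), and 4-butylphenyl in place of heptyl on the oxygen gave an at least 4.5-fold higher number from compound 2 to compound 3 (0.65 log units; beyond the scatter). Neither step alters the acetamido group, so both serve only as a rough guide to size and leave the direction open.

No change beyond the scatter is expected in this assay, and the estimated step is a 1.0-fold lower number from compound 2 to compound 4 (0.02 log units; within the scatter). For compound 4 the expected value is 17000 nM, with an estimated range of 6000 nM to 50000 nM.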

Compound 4, half-maximal inhibitory concentration: 21400 nM
Compound 4: middle estimate off by 1.3-fold (0.10 log units), on the low side; the measured number falls inside the stated range.
By their numbers in this assay, from the lowest: compounds 2, 4 and 1 (each within the scatter of the next, the first and the last beyond it). At a limit, above all of these: compound 3.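

In this assay, putting tert-butoxy in place of methyl on the carbonyl carbon gives a 1.2-fold higher number from compound 2 to compound 4 (0.08 log units; within the scatter). Acetamido and (tert-butoxycarbonyl)amino are therefore not told apart here, even though tert-butoxy holds more heavy atoms, and this is the first change shown at this place rather than on the oxygen side chain. Nothing shown gives a reason for this result.

Still open, going by these compounds, is whether a free amine in place of acetamido would move the number beyond the scatter. Also open, on these data alone, is whether (tert-butoxycarbonyl)amino behaves the same way alongside the octyl chain of compound 1.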